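Chloro Substitution on the Phenyl of Compound 3

This account rests on a few compounds, and the source may have more. Where it says the series, first, only, none or still open, it means among the compounds named here.

Among the compounds with values here, compound 3 `O=C(O)c1csc(SCCN2C(=O)CC[C@@H]2/C=C/[C@@H](O)Cc2cccc(-c3ccccc3)c2)n1` is the only one of the three compounds with a numerical result: in an assay on CHO cells for displacement of a labelled ligand from prostaglandin E2 receptor EP3 subtype (Mus musculus), read by scintillation counting, with a stated time of 60 min (on this read-out higher numbers stand for weaker inhibition and lower numbers for stronger inhibition), compound 3 gives 4300 nM. Compound 1 `O=C(O)CCCSCCN1C(=O)CC[C@@H]1/C=C/[C@@H](O)Cc1cccc(-c2ccc3[nH]ccc3c2)c1` gives > 10000 nM in this assay, which is a limit of the assay. Compound 2 `O=C(O)CCCSCCN1C(=O)CC[C@@H]1/C=C/[C@@H](O)Cc1cccc(-c2cc3ccccc3o2)c1` likewise gives > 10000 nM in this assay, also a limit. Hence a step that the two limits leave unreadable from compound 1 to compound 2 cannot be read, and compound 3 stands apart from the limit of > 10000 nM in this assay, at which 2 of the 3 values shown sit. Compound 4 `O=C(O)c1csc(SCCN2C(=O)CC[C@@H]2/C=C/[C@@H](O)Cc2cccc(-c3ccc(Cl)cc3)c2)n1` carries chloro in place of hydrogen on an aromatic carbon, placed para to a large group. Within the data shown here, no measured step touches this phenyl or a chloro group, so no measured step bears on the change. The step of a 1.2-fold lower number from compound 3 to compound 4 (0.09 log units; within the scatter) is therefore expected to lie within the scatter, in no set direction. The estimate for compound 4 is 3500 nM, with a range from 1200 nM to 12000 nM.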

Compound 4, inhibition constant: > 10000 nM
Compound 4 ended at the assay's limit; the forecaster's own chance of this, stated with the estimate: 25%; at least 2.8-fold (0.45 log units) between middle value and limit.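

Chloro in place of hydrogen on this phenyl gives an at least 2.3-fold higher number from compound 3 to compound 4 (0.36 log units; beyond the scatter) in this assay, the first readable step among the compounds shown, and it points towards weaker inhibition. The value of compound 4 is a limit, so the step fixes only the smallest possible size of this loss. Compound 3 remains the only compound with a number: the limit of > 10000 nM in this assay, at which 3 of the 4 values shown sit.

Going by these compounds, whether a fluoro, methoxy or hydroxyl group at the same place would keep a number stays open. So does whether chloro elsewhere on this phenyl would.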